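The compounds below may be only part of what the source reports. "The series", "measured", "known", "first", "only" and "open" are said of these compounds alone.

Measured in a functional assay on K562 cells (Homo sapiens) for cytotoxicity, read by MTT assay, with a stated time of 24 h; a lower number here means a stronger inhibitor, a higher number a weaker inhibitor:
- compound 1 `COc1cc(/C=C2\CN(C)C/C(=C\c3ccc(Cl)cc3)C2=O)cc(OC)c1`: 13300 nM
- compound 2 `COc1cc(/C=C2\CN(C)C/C(=C\c3ccc(Br)cc3)C2=O)cc(OC)c1`: 7420 nM

Among the measured compounds shown here, compound 2 stands within the usual scatter of compound 1, the only other compound measured so far. Next comes compound 3 `COc1cc(/C=C2\CN(C)C/C(=C\c3cccc([N+](=O)[O-])c3)C2=O)cc(OC)c1`, and the change is 3-nitrophenyl in place of 4-bromophenyl on a double-bonded chain carbon bound to a double-bonded ring carbon. Put simply, it is 3-nitrophenyl in place of 4-bromophenyl on a double-bonded chain carbon bound to a double-bonded ring carbon.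

For the measured compounds named here, only one measured step bears on this: bromo in place of chloro on an aromatic carbon, which gave a 1.8-fold lower number from compound 1 to compound 2 (0.25 log units; within the scatter). That step is a guide of limited reach, since it swaps one atom on the ring, while the new change replaces the whole 4-bromophenyl group. Going by the values given here, no measured compound carries a nitro group, so the data offer no direction for this change. Among the compounds with values here, with only that small step to go on, no step beyond the scatter is expected in this assay, though the uncertainty is wide. The expected result is a 1.2-fold higher number from compound 2 to compound 3 (0.08 log units; within the scatter). For compound 3 the estimated value is 9000 nM, with an expected range from 3000 nM to 27000 nM.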

Compound 3, half-maximal inhibitory concentration: 4420 nM
Compound 3: middle estimate off by 2.0-fold (0.31 log units), on the high side; low and high end bracket the measured number.
By their numbers in this assay, from the lowest: compounds 3, 2 and 1 (each within the scatter of the next, the first and the last beyond it).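

In this assay, the position on a double-bonded chain carbon bound to a double-bonded ring carbon now proves open to more than a single-atom swap on the ring: replacing the whole 4-bromophenyl group with 3-nitrophenyl gives a 1.7-fold lower number from compound 2 to compound 3 (0.22 log units; within the scatter), so this larger change leaves the number within the scatter. Set against the 4-chlorophenyl group, the same 3-nitrophenyl group gives a 3.0-fold lower number from compound 1 to compound 3 (0.48 log units; beyond the scatter), a modest difference and the only one among these three compounds that clears the scatter. No measurement available here accounts for either step.

The compounds shown leave open how much of this result belongs to the nitro group itself and how much to its place on the phenyl ring, as the two change together in this single replacement. They also leave open whether an amine, a carboxylic acid or a methoxy group on that phenyl ring would stay within the same range in this assay, or whether a longer chain at this position would be accepted as well.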